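Pyrazole series: cytotoxicity read-out, acetyl to dimethylamino step

The source may hold more compounds than are shown below. What is called first, only, known or untested is meant among the compounds shown, and "the series" means these compounds.

Measured compounds:
compound 1 `COc1cc(C)cc(-c2c(-c3ccnc(-c4ccc(C(C)=O)cc4)c3)cnn2CC#N)c1`: 69%
compound 2 `COc1cc(C)cc(-c2nn(CC#N)cc2-c2ccc(-c3cccc(C(C)=O)c3)nc2)c1`: 24%
compound 3 `Cc1cc(O)cc(-c2nn(CC#N)cc2-c2ccnc(-c3ccc(Oc4ccccc4)cc3)c2)c1`: 35%

In a functional assay on NCI-H322M cells (Homo sapiens) for cytotoxicity, read by sulforhodamine B assay, with a stated time of 48 h, tested at 1 uM (a lower number here means a stronger effect, a higher number a weaker effect of the compound at the concentration tested), compound 1 gives 69%, the highest of the three numbers, which here means the weakest effect. Compound 3 stands nearest to it, with a number lower by a gap beyond the scatter; compound 2 stands furthest, lower by a still larger gap, also beyond the scatter. None of these pairs differs in only one place, so the three values show only where each compound stands, not what any single change does.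

The next compound is compound 4 `COc1cc(C)cc(-c2c(-c3ccnc(-c4ccc(N(C)C)cc4)c3)cnn2CC#N)c1`. It differs from compound 1 in one place: dimethylamino in place of acetyl on an aromatic carbon. The counts under the difference show the same number of heavy atoms leaving and entering, with one hydrogen-bond acceptor on each side, and no ring on either side.

Among the measured compounds shown here, no step of this kind has been measured, so its size rests on no direct comparison. The expectation is a modest move towards a lower number, of a size that may or may not clear the scatter, as a number 14 percentage points lower from compound 1 to compound 4 (beyond the scatter) in this assay. In this assay compound 4 is therefore estimated at 55%, within a range from 30% to 85%.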

Compound 4, a percentage reported as activity, at one concentration (the size of the read-out at that concentration, not a potency): 34%
Compound 4: middle estimate off by 21 percentage points, on the high side; measured number inside the range.
By their numbers in this assay, from the lowest: compounds 2, 4 and 3 (each within the scatter of the next, the first and the last beyond it); then compound 1.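

In this assay, among the compounds shown here, the change from 4-acetylphenyl to 4-(dimethylamino)phenyl gives a number 35 percentage points lower from compound 1 to compound 4 (beyond the scatter) and is the only one-place comparison, so it shows that the group at this place on the six-membered aromatic ring of carbon only has a bearing on the read-out at the concentration tested. The two groups have the same count of heavy atoms and of hydrogen-bond acceptors, and neither has a ring, so these counts alone do not predict the read-out here; the counted differences are that nitrogen replaces oxygen and that the double bond outside aromatic rings leaves. No measurement on these groups is available to account for the size of the step.

As far as these compounds go, with a single step, it remains open whether the same change would have a similar size on the other compounds. From the compounds shown here alone, it also remains open how a primary amine, a morpholine ring or a carboxylic acid at this place would read in this assay, and whether the read-out follows dimethylamino or acetyl.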